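A few compounds are considered here, and "the series" means these few. Any claim that something is new, unique, unknown or untested is made for them only; others in the source may bear on it.

Among the compounds with values here, in a functional assay on PC-3 cells (Homo sapiens) for cytotoxicity, read by MTT assay, with a stated time of 72 h (a higher number here means a weaker inhibitor, a lower number a stronger inhibitor), compound 2 `CCc1ccc(-c2cc(C(=O)Nc3ccc(Oc4ccnc(C(=O)NC)c4)c(F)c3)ncn2)cc1` gives 15600 nM, the only actual number so far. Compound 1 `CNC(=O)c1cc(Oc2ccc(NC(=O)c3cc(-c4ccc(Cl)cc4)ncn3)cc2F)ccn1` reads > 100000 nM, which is a limit of the assay. Within the data shown here, the one measured step, an at least 6.4-fold lower number from compound 1 to compound 2 (0.80 log units; beyond the scatter), places ethyl where chloro stood on an aromatic carbon. Compound 3 `CNC(=O)c1cc(Oc2ccc(NC(=O)c3cc(-c4ccc(C)cc4)ncn3)cc2F)ccn1` differs from compound 2 by hydrogen in place of methyl on a saturated chain carbon bound to an aromatic carbon, with hydrogen in place of methyl on a saturated chain carbon bound to an aromatic carbon, turning ethyl to methyl. Resting on an at least 6.4-fold lower number from compound 1 to compound 2 (0.80 log units; beyond the scatter) alone, a modestly higher number is expected in this assay. The expected step is a 2.2-fold higher number from compound 2 to compound 3 (0.35 log units; beyond the scatter). For compound 3 the estimate is 35000 nM, ranging from 14000 nM to 90000 nM.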

Compound 3, half-maximal inhibitory concentration: 40200 nM
For compound 3 the middle estimate is 1.1-fold (0.06 log units) below the measured one; the range from low to high includes it.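

Shortening ethyl to methyl gives a 2.6-fold higher number from compound 2 to compound 3 (0.41 log units; beyond the scatter) in this assay, so a single methyl on this saturated chain carbon moves the number beyond the scatter, whereas the earlier step only exchanged chloro for ethyl. Methyl also stands apart from chloro, with an at least 2.4-fold lower number from compound 1 to compound 3 (0.39 log units; beyond the scatter), which puts the numbers in the order ethyl, methyl, chloro from lowest to highest. The chloro end of that order is only a bound: the limit of > 100000 nM in this assay, at which 1 of the 3 values shown sits.

The compounds shown leave open whether a longer chain such as propyl, or an amine in place of the ethyl, would lower the number further.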